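The compounds below may be only part of what the source reports. "The series", "measured", "known", "first", "only" and "open" are said of these compounds alone.

compound 1 (`CC(c1ccccc1)c1cc(O)nc(SC2CCCCC2)n1`) gives 149000 nM
compound 2 (`CC(C)Sc1nc(O)cc(C(C)c2c(Cl)cccc2Cl)n1`) gives 117000 nM
compound 3 (`CCC(c1cc(O)nc(SC(C)C)n1)c1c(Cl)cccc1Cl`) gives > 200000 nM as a limit
compound 4 (`CC(c1cc(O)nc(SC2CCCCC2)n1)c1c(Cl)cccc1Cl`) is not yet measured

In a functional assay on MT4 cells (Homo sapiens) for cytotoxicity (on this read-out higher numbers stand for lower toxicity in this test and lower numbers for higher toxicity in this test), compound 2 gives 117000 nM and compound 1 gives 149000 nM within the scatter of it. Compound 3 reads > 200000 nM and that is a limit.

The step to compound 4 is cyclohexyl in place of isopropyl on a sulfur and reads in words as cyclohexyl in place of isopropyl on a sulfur. For the measured compounds named here, no measured step makes this same change. Going by the values given here, the one step at hand, an at least 1.7-fold higher number from compound 2 to compound 3 (0.23 log units; that floor lies within the scatter) for methyl in place of hydrogen on a saturated chain carbon, lies elsewhere in the structure and its floor is within the scatter. Compound 1 also carries cyclohexyl on a sulfur, and at 149000 nM it stays within the scatter of compound 2, so no step beyond the scatter is expected in this assay here. The expected step is a 1.1-fold lower number from compound 2 to compound 4 (0.03 log units; within the scatter) and no firm direction is expected for it. For compound 4 the estimated value is 110000 nM with an expected range from 45000 nM to 200000 nM around it.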

Compound 4, half-maximal cytotoxic concentration: > 200000 nM
Compound 4 was reported as a limit; the forecaster's own chance of this, stated with the estimate: 30%; middle value at least 1.8-fold (0.25 log units) from the limit.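

Cyclohexyl in place of isopropyl on a sulfur can now be read directly in this assay, as an at least 1.7-fold higher number from compound 2 to compound 4 (0.23 log units; that floor lies within the scatter). The change of phenyl to 2,6-dichlorophenyl on a saturated chain carbon with cyclohexyl kept on the sulfur reads as an at least 1.3-fold higher number from compound 1 to compound 4 (0.12 log units; that floor lies within the scatter). Both floors lie within the scatter, so neither change is shown to move the read-out beyond it, and the full size of both steps stays open, compound 4 being a limit: the limit of > 200000 nM in this assay, at which 2 of the 4 values shown sit.

Only isopropyl and cyclohexyl appear on the sulfur in the compounds shown, so the effect of an amine, a carboxylic acid or a longer chain there remains open. Also open, from the compounds shown here alone, is whether any change gives a step beyond the scatter in this assay.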